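This account rests on a few compounds, and the source may have more. Where it says the series, first, only, none or still open, it means among the compounds named here.

Compound 3 `CC(C)C[C@H](N)c1cc(C(F)(F)F)ccc1N1CCN(C(=O)CCNC2CCCCC2)CC1` stands at the top of the three numbers measured in an assay on HEK293 cells for displacement of a labelled ligand from Melanocortin receptor 4 (Homo sapiens); a lower number here means a stronger inhibitor, a higher number a weaker inhibitor: compound 3 gives 4800 nM, while compound 2 `Cc1ccc(OCC(=O)N2CCN(c3ccc(C(F)(F)F)cc3[C@@H](N)CC(C)C)CC2)cc1` gives 4400 nM and compound 1 `CC(C)C[C@H](N)c1cc(C(F)(F)F)ccc1N1CCN(C(=O)[C@H](C)Cc2ccc(Cl)cc2)CC1` gives 31 nM. The gap a 1.1-fold higher number from compound 2 to compound 3 (0.04 log units; within the scatter) lies within the scatter, so compound 2 and compound 3 cannot be told apart; the step of a 150-fold higher number from compound 1 to compound 3 (2.19 log units; beyond the scatter) is large, as is a 140-fold higher number from compound 1 to compound 2 (2.15 log units; beyond the scatter). Compound 4 `CC(C)C[C@H](N)c1cc(C(F)(F)F)ccc1N1CCN(C(=O)COc2ccc(O)cc2)CC1` differs from compound 3 by 4-hydroxyphenoxy in place of (cyclohexylamino)methyl on a saturated chain carbon bound to a carbonyl carbon. Within the data shown here, two measured steps bear on this change. The step of a 1.1-fold higher number from compound 2 to compound 3 (0.04 log units; within the scatter) shows that exchanging the (cyclohexylamino)methyl of compound 3 for the 4-methylphenoxy of compound 2 left this assay unchanged. The step of a 150-fold higher number from compound 1 to compound 3 (2.19 log units; beyond the scatter) shows that a far stronger number is reachable, but compound 1 carries a 1-(4-chlorobenzyl)ethyl group that compound 4 does not share. Among the measured compounds shown here, compound 4 resembles compound 2 most closely, a 4-hydroxyphenoxy standing where compound 2 has 4-methylphenoxy, and no measured step separates those two groups. Compound 4 is therefore expected to change little from compound 3, the expected step being a 1.1-fold lower number from compound 3 to compound 4 (0.03 log units; within the scatter). The estimate for compound 4 in this assay is 4500 nM, with a range from 1500 nM to 14000 nM.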

Compound 4, inhibition constant: 4600 nM
The estimate for compound 4 lay 1.0-fold (0.01 log units) below the measured number, and the stated range covers the measured number.
By their numbers in this assay, from the lowest: compound 1; then compounds 2, 4 and 3 (each within the scatter of the next).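

Hydroxy in place of methyl on an aromatic carbon now has a direct reading in this assay: a 1.0-fold higher number from compound 2 to compound 4 (0.02 log units; within the scatter), so these two groups cannot be told apart here. The exchange of (cyclohexylamino)methyl for 4-hydroxyphenoxy, on a saturated chain carbon bound to a carbonyl carbon, gives a 1.0-fold lower number from compound 3 to compound 4 (0.02 log units; within the scatter), so a six-membered ring of carbon joined through nitrogen and an aromatic ring joined through oxygen read alike at this place, and the two earlier compounds' agreement extends to a third group. The large step of a 150-fold higher number from compound 1 to compound 4 (2.17 log units; beyond the scatter) shows that the gap to compound 1 stays in place with this further group, and nothing among the data shown gives a reason for that gap or for the flat readings.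

The compounds shown leave open whether a 4-chlorophenoxy group, which would carry the chlorine of compound 1 on a phenoxy ring, would stay with compound 2, compound 3 and compound 4 or move towards compound 1. They also leave open whether the methyl branch of the 1-(4-chlorobenzyl)ethyl group or its chlorine matters more, as a 4-chlorobenzyl group without that branch would begin to tell.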